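A Fluorophenyl Variant Joins Three Compounds at the Limit

This account rests on a few compounds, and the source may have more. Where it says the series, first, only, none or still open, it means among the compounds named here.

Compound 3 `O=[N+]([O-])c1ccc(CN2CCC(n3cc(CC(OCc4cc(-c5cccc(Br)c5)no4)c4ccc(Br)cc4)nn3)CC2)cc1` belongs to a small set of three close relatives that share one core and differ only in the group attached to the five-membered aromatic ring with one nitrogen and one oxygen. In a functional assay on PC-3 cells (Homo sapiens) for cytotoxicity, with a stated time of 48 h (on this read-out higher numbers stand for weaker inhibition and lower numbers for stronger inhibition), compound 3 gives > 25000 nM, which is a limit of the assay and not a number. Compound 1 `O=[N+]([O-])c1ccc(CN2CCC(n3cc(CC(OCc4cc(-c5ccc(Br)cc5)no4)c4ccc(Br)cc4)nn3)CC2)cc1` gives > 25000 nM in this assay, again a limit rather than a number. Compound 2 `O=[N+]([O-])c1ccc(CN2CCC(n3cc(CC(OCc4cc(-c5ccc(F)cc5)no4)c4ccc(Br)cc4)nn3)CC2)cc1` likewise gives > 25000 nM, also a limit. Because (the limit of > 25000 nM in this assay, at which 3 of the 3 values shown sit), none of the three steps among them can be read: a step that the two limits leave unreadable from compound 1 to compound 2, a step that the two limits leave unreadable from compound 1 to compound 3 and a step that the two limits leave unreadable from compound 2 to compound 3 all remain unreadable in size. Compound 4 `O=[N+]([O-])c1ccc(CN2CCC(n3cc(CC(OCc4cc(-c5ccccc5F)no4)c4ccc(Br)cc4)nn3)CC2)cc1` continues the series with the change (2-fluorophenyl in place of 3-bromophenyl on an aromatic carbon). The measured steps that bear on it are of the same kind, a swap of halogen and of its place on the phenyl group, and each of them was unreadable. There is therefore no ground for expecting a step beyond the scatter. The step that the limit leaves unreadable from compound 3 to compound 4 is estimated to be none beyond the scatter, with the most likely outcome once more a limit. Compound 4 is thus expected to give about 40000 nM, with a range from 12000 nM to 150000 nM.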

Compound 4, half-maximal inhibitory concentration: 6000 nM
Compound 4: middle estimate off by 6.7-fold (0.82 log units), on the high side; measured number outside the range, below it.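

In this assay, for the compounds shown here, the group on this aromatic carbon turns out to be able to shift the read-out, which the earlier compounds could not show: putting in 2-fluorophenyl gives an at least 4.1-fold lower number from compound 3 to compound 4 (0.61 log units; beyond the scatter) against 3-bromophenyl, an at least 4.1-fold lower number from compound 2 to compound 4 (0.61 log units; beyond the scatter) against 4-fluorophenyl and an at least 4.1-fold lower number from compound 1 to compound 4 (0.61 log units; beyond the scatter) against 4-bromophenyl. The second of these changes keeps the fluorine and alters only its place on the phenyl group, so a change of place alone is enough to give a step beyond the scatter in this pair. These sizes are only lower bounds, and the steps among compound 1, compound 2 and compound 3 stay unreadable, because the other values sit at a limit: the limit of > 25000 nM in this assay, at which 3 of the 4 values shown sit.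

The compounds shown leave open whether the step in compound 4 belongs to fluorine in particular or to any halogen at that place on the phenyl group, a question that a 2-bromophenyl or 2-chlorophenyl group would address. On these data alone, how a 3-fluorophenyl group, a plain phenyl group or a 2-methoxyphenyl group would read at this position also remains open.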